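Methoxy on the anilino ring of a thiazolyl acetamide

The compounds below may be only part of what the source reports. "The series", "measured", "known", "first", "only" and "open" are said of these compounds alone.

Compound 1: `Cc1nc(SCC(=O)Nc2nc(-c3ccc(Cl)cc3)cs2)n(Nc2ccccc2)c1C`, 16500 nM
Compound 2: `Cc1ccc(Nn2c(SCC(=O)Nc3nc(-c4ccccc4)cs3)nc(C)c2C)cc1`, 5890 nM

In a functional assay on SF-295 cells (Homo sapiens) for antiproliferative activity, read by sulforhodamine B assay, with a stated time of 48 h (on this read-out higher numbers stand for weaker inhibition of growth and lower numbers for stronger inhibition of growth), compound 1 gives 16500 nM, the highest of the two numbers measured, while compound 2 gives 5890 nM, a lower number that lies beyond the scatter; since these two compounds differ in more than one place, only their two values can be set side by side.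

Compound 3, `COc1ccc(Nn2c(SCC(=O)Nc3nc(-c4ccc(Cl)cc4)cs3)nc(C)c2C)cc1`, has not been measured. It differs from compound 1 by methoxy in place of hydrogen on an aromatic carbon, on the six-membered carbon ring that hangs from the core, para to a large group. Within the data shown here, nothing among the measured compounds isolates this change, so its effect can only be guessed.

The expected step from compound 1 to compound 3 is a 2.1-fold lower number from compound 1 to compound 3 (0.31 log units; beyond the scatter), a modest move towards stronger inhibition of growth. Compound 3 is estimated at 8000 nM, within a range from 2500 nM to 30000 nM.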

Compound 3, concentration for total growth inhibition: > 100000 nM
Compound 3: only a limit was reported; the forecaster's own chance of this, stated with the estimate: 15%; middle value at least 12-fold (1.09 log units) away from the limit.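

Compound 3 gives no number in this assay, only a limit, > 100000 nM. Even so, the pair isolates this position for the first time: methoxy in place of hydrogen on an aromatic carbon of the anilino ring, para to a large group, gives an at least 6.0-fold higher number from compound 1 to compound 3 (0.78 log units; beyond the scatter), so this single change moves the read-out towards weaker inhibition of growth. How far the step truly reaches cannot be read, and what stands behind it is only this: the limit of > 100000 nM in this assay, at which 1 of the 3 values shown sits.

The compounds shown leave open whether the loss belongs to methoxy itself or would also follow from another group at this place, such as a hydroxy group, a fluorine atom or an amine. They also leave open whether methoxy would act in the same way on a compound without the chlorine of compound 1.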